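The compounds below may be only part of what the source reports. "The series", "measured", "known", "first", "only" and "open" are said of these compounds alone.

Measured in a physicochemical assay for acid dissociation, so far:
- compound 1 (`O=C(NCCCNC1CCCCC1)[C@H]1C[C@@H]1c1ccccc1`) gives 10.1; 10.4; 10.4 (3 entries)
- compound 2 (`CCN(CC)CCNC(=O)[C@H]1C[C@@H]1c1ccccc1`) gives 8.9

The spread of repeat entries for a single compound can be seen in the several entries of compound 1 in this assay, 10.1; 10.4; 10.4 (3 entries) within this series. Compound 2 rests on one number, and its further entry carries no single number. In this assay compound 1 gives 10.1; 10.4; 10.4 (3 entries) and compound 2 gives 8.9. On the values shown, compound 2 stands lower than compound 1.

Compound 3 (`CC(C)N(CCNC(=O)[C@H]1C[C@@H]1c1ccccc1)C(C)C`) differs from compound 2 by one change (diisopropylamino in place of diethylamino on a saturated chain carbon, two bonds along the chain from an amide-type nitrogen) with diisopropylamino in place of diethylamino on a saturated chain carbon, two bonds along the chain from an amide-type nitrogen. Among the compounds with values here, no measured pair shows this change. The expected step is small and upward (a number 0.20 log units higher from compound 2 to compound 3 (within the scatter)) and is not expected to pass beyond the usual scatter. For compound 3 the estimated value is 9.1 with an expected range from 8.7 to 9.6 around it.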

Compound 3, acid dissociation constant: 9.7
Beside the measured number, compound 3's estimate is 0.60 log units below it, and the stated range ends below it.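

In this assay, diisopropylamino in place of diethylamino on a saturated chain carbon, two bonds along the chain from an amide-type nitrogen, gives a number 0.80 log units higher from compound 2 to compound 3 (beyond the scatter). Within the data shown here, this is the first measured pair for any change at this position, and it shows that exchanging these two groups, with the rest of the structure held the same, can move the read-out by more than repeat measurements would. Each side of the pair rests on one number, and the only view of repeat spread in this series comes from another compound: the several entries of compound 1 in this assay, 10.1; 10.4; 10.4 (3 entries)

Going by these compounds, one pair gives one step, so it remains open whether the same exchange would give a step of similar size on a different chain. On these data alone, how dimethylamino or morpholine would read at this position in this assay also remains open.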